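This account rests on a few compounds, and the source may have more. Where it says the series, first, only, none or still open, it means among the compounds named here.

Measured so far:
- compound 1 `Cc1cc(-c2sc(Cc3cccc(N(C)C)c3)nc2C)ccc1C(N)=O` — 101%
- compound 2 `Cc1cc(-c2sc(Cc3cccc(F)c3)nc2C)ccc1C(N)=O` — 75%
- compound 3 `Cc1cc(-c2sc(Cc3cccc(Cl)c3)nc2C)ccc1C(N)=O` — 75%

In a functional assay on cells for agonist activity at G-protein coupled receptor 52 (Homo sapiens), read by AlphaScreen and cAMP accumulation, with a stated time of 30 min (on this read-out lower numbers stand for smaller maximal responses and higher numbers for larger maximal responses), compound 3 stands level with compound 2, the pair together giving the lowest numbers of the three; no change at the digits printed from compound 2 to compound 3 (within the scatter). Compound 1 sits apart: a number 26 percentage points lower from compound 1 to compound 2 (beyond the scatter) and a number 26 percentage points lower from compound 1 to compound 3 (beyond the scatter).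

Compound 4 `Cc1cc(-c2sc(Cc3cc(F)cc(Cl)c3)nc2C)ccc1C(N)=O` differs from compound 3 by fluoro in place of hydrogen on an aromatic carbon. For the measured compounds named here, the only step that bears on a halogen on that ring is the one from compound 2 to compound 3, which stayed within the scatter; no measured step adds a second halogen to a ring already carrying one. The expectation for compound 4 in this assay is therefore a step of about no change at the digits printed from compound 3 to compound 4 (within the scatter), none beyond the scatter. Compound 4 is estimated at 75%, within 60% to 90%.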

Compound 4, largest response reached (Emax), in percent of the reference or control that the assay uses: 88%
Compound 4: middle estimate off by 13 percentage points, on the low side; measured number inside the range.
By their numbers in this assay, from the lowest: compounds 2 and 3 (each within the scatter of the next); then compound 4; then compound 1.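

In this assay, going from 3-chlorophenyl to 3-chloro-5-fluorophenyl gives a number 13 percentage points higher from compound 3 to compound 4 (beyond the scatter), and the same ring reached by adding chloro to the fluoro ring gives a number 13 percentage points higher from compound 2 to compound 4 (beyond the scatter). Exchanging one halogen for the other had stayed within the scatter, whereas a second halogen on this ring moves the number beyond it. Nothing available explains this shift. As far as these compounds go, whether a second chloro or a methoxy group on this ring would shift the number in the same way stays open, as does the effect of fluoro added to the dimethylamino ring.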